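The compounds below may be only part of what the source reports. "The series", "measured", "known", "first", "only" and "open" are said of these compounds alone.

Measured compounds: compound 1 `Cc1cc(O)cc(-c2nn(CC#N)cc2-c2ccnc(-c3ccc(Oc4ccccc4)cc3)c2)c1`, compound 2 `COc1cc(C)cc(-c2nn(CC#N)cc2-c2ccnc(-c3ccc(N(C)C)cc3)c2)c1`.

In a functional assay on HOP-92 cells (Homo sapiens) for inhibition, read by sulforhodamine B assay, with a stated time of 48 h (on this read-out higher numbers stand for weaker inhibition of growth and lower numbers for stronger inhibition of growth), compound 1 gives 1590 nM. In this assay compound 2 gives 557 nM, the lowest of the two numbers; compound 1 sits at the higher number, and that gap is beyond the scatter. Compound 3 `Cc1cc(O)cc(-c2nn(CC#N)cc2-c2ccnc(-c3ccc(N(C)C)cc3)c2)c1` differs from compound 2 by hydrogen in place of methyl on an oxygen on an aromatic ring. Going by the values given here, no pair of measured compounds isolates this change, as compound 1 and compound 2 differ in more than one place. The change is expected to shift the number only a little, in either direction, likely not beyond the scatter. Compound 3 is expected to give 650 nM, within 250 nM to 1700 nM, an expected step of a 1.2-fold higher number from compound 2 to compound 3 (0.07 log units; within the scatter).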

Compound 3, concentration for 50% growth inhibition: 3030 nM
Compound 3: the middle estimate sits 4.7-fold (0.67 log units) below what was measured; measured number above the stated range.
By their numbers in this assay, from the lowest: compound 2; then compounds 1 and 3 (each within the scatter of the next).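

In this assay, the change from methoxy to hydroxy on the aromatic ring is now isolated (a 5.4-fold higher number from compound 2 to compound 3 (0.74 log units; beyond the scatter)), so the methyl on this oxygen goes with stronger inhibition of growth in this pair. With the hydroxy kept, dimethylamino in place of phenoxy on an aromatic carbon leaves the two compounds within the scatter (a 1.9-fold higher number from compound 1 to compound 3 (0.28 log units; within the scatter)). No measured property on hand accounts for the methoxy to hydroxy step.

From the compounds shown here alone, whether ethyl on this oxygen keeps the number of compound 2 remains open. Also open, going by these compounds, is whether the methoxy to hydroxy step recurs with phenoxy in place of dimethylamino.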